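Swapping methyl for fluoro on a weakly active series

A few compounds are considered here, and "the series" means these few. Any claim that something is new, unique, unknown or untested is made for them only; others in the source may bear on it.

Measured in a functional assay on HL-60 cells (Homo sapiens) for inhibition, read by CCK-8 assay, with a stated time of 48 h, tested at 20 uM; a higher number here means more inhibition of growth at the concentration tested, a lower number less inhibition of growth:
- compound 1 `COc1ccc(Cc2nnc(NC(=O)/C(C#N)=C/c3ccccc3OS(=O)(=O)c3ccc(C)cc3)s2)cc1`: 25%
- compound 2 `N#C/C(=C\c1ccccc1OS(=O)(=O)c1ccc(F)cc1)C(=O)Nc1nnc(Cc2ccc(F)cc2)s1`: 13%
- compound 3 `Cc1ccc(S(=O)(=O)Oc2ccccc2/C=C(\C#N)C(=O)Nc2nnc(Cc3ccc(Cl)cc3)s2)cc1`: 15%

All three values lie within the usual scatter of one another, so compound 3, at 15%, cannot be ranked firmly against either neighbour.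

The next compound, compound 4 `N#C/C(=C\c1ccccc1OS(=O)(=O)c1ccc(F)cc1)C(=O)Nc1nnc(Cc2ccc(Cl)cc2)s1`, has fluoro in place of methyl on an aromatic carbon, para to a large group: fluoro in place of methyl on an aromatic carbon. Among the measured compounds shown here, no measured step covers this exact swap. For the measured compounds named here, the only measured single-place step is a number 10 percentage points lower from compound 1 to compound 3 (within the scatter). It involves chloro in place of methoxy on an aromatic carbon, which is a different change, so it offers only a rough guide to how far one small swap can move this read-out. Since that step stayed within the scatter, no step beyond the scatter is expected in this assay, and no clear direction can be predicted. The expected step is a number 1 percentage points lower from compound 3 to compound 4 (within the scatter).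

For compound 4 the estimate is 14%, with an expected range of 5% to 25%.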

Compound 4, percent growth inhibition at one concentration: 20%
For compound 4 the middle estimate is 6 percentage points below the measured one, within the range that was stated.
By their numbers in this assay, from the lowest: compounds 2, 3, 4 and 1 (each within the scatter of the next, the first and the last beyond it).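

In this assay, fluoro in place of methyl, para to a large group, gives a number 5 percentage points higher from compound 3 to compound 4 (within the scatter), so 4-fluorophenyl and 4-methylphenyl cannot be told apart at this position in this read-out. The other new comparison, chloro in place of fluoro on an aromatic carbon, gives a number 7 percentage points higher from compound 2 to compound 4 (within the scatter), so that small swap cannot be told apart from no change either. The data offer no measurement that could explain either step.

As far as these compounds go, it remains open whether a group of a different kind at this position, such as an amine or a carboxylic acid in place of the fluoro, would move growth inhibition beyond the scatter. Also open, from the compounds shown here alone, is whether this position influences the read-out at all, since both swaps at one atom leave the values too close to separate.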